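The source may hold more compounds than are shown below. What is called first, only, known or untested is meant among the compounds shown, and "the series" means these compounds.

Measured in an ADME assay on SH-SY5Y cells (Homo sapiens) for cytotoxicity, read by MTT assay, with a stated time of 72 h; a lower number here means a stronger inhibitor, a higher number a weaker inhibitor:
- Compound 1 `O=C(CN1CCN(C(=O)c2ccc(Br)cc2)CC1)N1CCN(CCCc2c[nH]c3ccccc23)CC1`: 59300 nM
- Compound 2 `Cc1ccc(C(=O)N2CCN(CC(=O)N3CCN(CCCc4c[nH]c5ccccc45)CC3)CC2)cc1`: > 200000 nM (a limit of the assay, not a number)
- Compound 3 `O=C(CN1CCN(C(=O)c2ccc(F)cc2)CC1)N1CCN(CCCc2c[nH]c3ccccc23)CC1`: 188000 nM

Compound 3 holds the higher of the two exact numbers, and compound 1 is its nearest neighbour, with a 3.2-fold higher number from compound 1 to compound 3 (0.50 log units; beyond the scatter). Against the limit of compound 2, the series shows an at least 1.0-fold lower number from compound 2 to compound 3 (0.02 log units; that floor lies within the scatter).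

The next change gives compound 4 `O=C(CN1CCN(C(=O)c2cccc(Cl)c2)CC1)N1CCN(CCCc2c[nH]c3ccccc23)CC1`, with 3-chlorophenyl in place of 4-fluorophenyl on a carbonyl carbon.

Among the compounds with values here, two measured steps bear on this, both swaps on the same aromatic group. Fluoro in place of bromo gave a 3.2-fold higher number from compound 1 to compound 3 (0.50 log units; beyond the scatter), and methyl in place of bromo gave an at least 3.3-fold higher number from compound 1 to compound 2 (0.52 log units; beyond the scatter). Neither involves chloro or moves a group around the ring, so they only frame the likely size. Within the data shown here, the one exact number lower than that of compound 3 belongs to bromo-bearing compound 1, at 59300 nM. In this assay, a lowering is therefore expected from the fluoro compound, of modest size at most and possibly no more than the scatter.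

The expected change is a 1.9-fold lower number from compound 3 to compound 4 (0.27 log units; within the scatter).

For compound 4 the estimated value is 100000 nM.

The estimated range for compound 4 runs from 45000 nM to 200000 nM.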

Compound 4, half-maximal inhibitory concentration: 120000 nM
Estimate against measurement, compound 4: 1.2-fold (0.08 log units) below; low and high end bracket the measured number.
By their numbers in this assay, from the lowest: compound 1; then compounds 4 and 3 (each within the scatter of the next). At a limit, above all of these: compound 2.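

In this assay, 3-chlorophenyl in place of 4-fluorophenyl on a carbonyl carbon gives a 1.6-fold lower number from compound 3 to compound 4 (0.19 log units; within the scatter). Compound 3 and compound 4 thus lie within the scatter of each other, even though the halogen and its place on the ring both change. Set against the bromo compound, 3-chlorophenyl in place of 4-bromophenyl gives a 2.0-fold higher number from compound 1 to compound 4 (0.31 log units; beyond the scatter), which leaves compound 1 as the only one of the three exact numbers set apart from the others, with compound 3 and compound 4 together on the higher side. Compound 2 stands at a limit of the assay, not at a number: the limit of > 200000 nM in this assay, at which 1 of the 4 values shown sits. Against that limit, 3-chlorophenyl in place of 4-methylphenyl gives an at least 1.6-fold lower number from compound 2 to compound 4 (0.22 log units; that floor lies within the scatter), which can be read only as a floor.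

Because compound 3 and compound 4 differ in both the halogen and its place on the ring, the compounds shown cannot separate these two changes, and they give no cause for the bromo compound standing apart. Also open, on these data alone, is how the number in this assay responds when an amine or a carboxylic acid takes the place of the halogen on this ring.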